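Adenosine-type series on HOS cells: first step

A few compounds are considered here, and "the series" means these few. Any claim that something is new, unique, unknown or untested is made for them only; others in the source may bear on it.

Measured so far:
compound 1, `COc1ccccc1CNc1ncnc2c1ncn2[C@@H]1O[C@H](CO)[C@@H](O)[C@H]1O`: > 166000 nM
compound 2, `OC[C@H]1O[C@@H](n2cnc3c(NCc4c(F)ccc(F)c4F)ncnc32)[C@H](O)[C@@H]1O`: "not determined" (no result reported)

In a functional assay on HOS cells (Homo sapiens) for antiproliferative activity, with a stated time of 72 h (on this read-out lower numbers stand for stronger inhibition and higher numbers for weaker inhibition), compound 1 gives > 166000 nM, and this is a limit of the assay rather than a number. For compound 2 this assay records "not determined" (no result reported). Thus the whole of what is known here is the limit of > 166000 nM in this assay, at which 1 of the 2 values shown sits; no pair of measured compounds differs in one place, so no measured step exists to lean on.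

The unmeasured compound 3 is `OC[C@H]1O[C@@H](n2cnc3c(NCc4ccc(F)c(Cl)c4)ncnc32)[C@H](O)[C@@H]1O`. It differs from compound 1 by 3-chloro-4-fluorophenyl in place of 2-methoxyphenyl on a saturated chain carbon bound to a nitrogen on an aromatic ring. Among the compounds with values here, the core and the sugar part are shared; the only change is 3-chloro-4-fluorophenyl in place of 2-methoxyphenyl on the saturated chain carbon bound to the nitrogen on the aromatic ring.

With compound 1 sitting at the limit, the step is expected to be small or none beyond the scatter, and the estimate for compound 3 is 150000 nM, with a range of 30000 nM to 500000 nM in this assay. The estimated step from compound 1 to compound 3 is an at least 1.1-fold lower number from compound 1 to compound 3 (0.04 log units; that floor lies within the scatter), and it is expected that this assay may again report only a limit for compound 3.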

Compound 3, half-maximal inhibitory concentration: > 166000 nM
Compound 3: a limit, no number; the forecaster's own chance of this, stated with the estimate: 60%; middle value at least 1.1-fold (0.04 log units) away from the limit.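

In this assay compound 3 gives > 166000 nM, a limit and not a number. Within the data shown here, compound 1 also stands at a limit, so no step between compound 1 and compound 3 can be read. Whether 2-methoxybenzyl and 3-chloro-4-fluorobenzyl differ at all on this read-out stays open, and the compounds shown offer only this: the limit of > 166000 nM in this assay, at which 2 of the 3 values shown sit.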